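Acetylation of the ring nitrogen in the amide series

This account rests on a few compounds, and the source may have more. Where it says the series, first, only, none or still open, it means among the compounds named here.

Compound 1 `O=C(Nc1ccccc1C(F)(F)F)C1CCc2ccccc2N1` gives 45500 nM in a functional assay on MDA-MB-231 cells (Homo sapiens) for cytotoxicity, read by sulforhodamine B assay, with a stated time of 72 h; on this read-out higher numbers stand for weaker inhibition of growth and lower numbers for stronger inhibition of growth. Of the two measured numbers, compound 1 carries the higher one; its nearest neighbour is compound 3 `O=C(Nc1ccccc1O)C1CCc2ccccc2N1`, which gives 5260 nM in this assay. Compound 2 `O=C(Nc1ccc(O)cc1)C1CCc2ccccc2N1` returns only a limit in this assay, > 100000 nM. Among the compounds with values here, the one connecting step, an 8.7-fold lower number from compound 1 to compound 3 (0.94 log units; beyond the scatter), changes the aryl amide substituent and leaves the ring nitrogen untouched.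

Compound 4 `CC(=O)N1c2ccccc2CCC1C(=O)Nc1ccccc1C(F)(F)F` differs from compound 1 by acetyl in place of hydrogen on a nitrogen on an aromatic ring in a ring. Within the data shown here, no measured step touches this ring nitrogen, so the step from compound 1 to compound 3 offers no guide to size or direction here. One further point bears on the outcome: the limit of > 100000 nM in this assay, at which 1 of the 3 values shown sits. The expectation is therefore no step beyond the scatter, with compound 4 estimated at a 1.3-fold higher number from compound 1 to compound 4 (0.12 log units; within the scatter) from compound 1. The estimate for compound 4 in this assay is 60000 nM, within 20000 nM and 150000 nM.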

Compound 4, concentration for 50% growth inhibition: > 80000 nM
Compound 4: a limit, no number; the forecaster's own chance of this, stated with the estimate: 40%; at least 1.3-fold (0.12 log units) between middle value and limit.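

Acetyl in place of hydrogen on a nitrogen on an aromatic ring in a ring is the first change shown at this position, and it gives an at least 1.7-fold higher number from compound 1 to compound 4 (0.24 log units; that floor lies within the scatter) in this assay. Compound 4 returns a limit, > 80000 nM, and not a number. The step therefore fixes only a floor: compound 4 shows no stronger inhibition of growth than compound 1, but whether the change weakens inhibition beyond the scatter cannot be read.

Still open, going by these compounds, is whether a methyl group or a longer acyl chain on this nitrogen would read differently from acetyl. Also open, on these data alone, is whether acetyl has the same outcome on compound 3, which gives 5260 nM in this assay.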